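Swapping the Ring on the Sulfonamide Nitrogen

The compounds below may be only part of what the source reports. "The series", "measured", "known", "first", "only" and "open" are said of these compounds alone.

Of the compounds shown here, three that share one core have been tested in an assay on CHO cells for displacement of a labelled ligand from prostaglandin E2 receptor EP1 subtype (Homo sapiens); on this read-out lower numbers stand for stronger inhibition and higher numbers for weaker inhibition. Compound 1 `CCc1ccccc1N(CC(=O)NCc1ccccc1)S(=O)(=O)c1ccc(C)cc1` gives 63.1 nM. Going by the values given here, compound 2 `CCc1ccccc1N(CC(=O)NCc1cccc(Cl)c1)S(=O)(=O)c1ccc(C)cc1` gives 251 nM, and the change a 4.0-fold higher number from compound 1 to compound 2 (0.60 log units; beyond the scatter) is the only single-point step among the measured compounds. Compound 3 `Cc1ccc(S(=O)(=O)N(CC(=O)NCc2ccc(Cl)cc2)c2cccnc2C)cc1` gives 200 nM; it stands second highest of the three numbers, within the scatter of compound 2 and beyond the scatter of compound 1, which gives a lower number.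

Compound 4 `Cc1ccc(S(=O)(=O)N(CC(=O)NCc2ccc(Cl)cc2)c2ccnn2C)cc1` differs from compound 3 in one place: 1-methyl-1H-pyrazol-5-yl in place of 2-methylpyridin-3-yl on a sulfonamide nitrogen. Among the compounds with values here, no measured step touches this part of the molecule, since the one known step concerns a chloro substituent on a different ring, so there is nothing here that points in either direction. The expectation for compound 4 is therefore a step of a 1.3-fold higher number from compound 3 to compound 4 (0.10 log units; within the scatter), not beyond the scatter. Compound 4 is estimated at 250 nM in this assay, with a range from 80 nM to 800 nM.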

Compound 4, inhibition constant: 398 nM
Compound 4: the middle estimate sits 1.6-fold (0.20 log units) below what was measured; the range from low to high includes it.
By their numbers in this assay, from the lowest: compound 1; then compounds 3, 2 and 4 (each within the scatter of the next).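

Going by these compounds alone, this is the first measured change to the ring on the sulfonamide nitrogen, and in this assay it amounts to a 2.0-fold higher number from compound 3 to compound 4 (0.30 log units; within the scatter). A six-membered aromatic ring with 1 hetero atom and 1 hydrogen-bond acceptor is replaced by a five-membered aromatic ring with 2 hetero atoms and 2 hydrogen-bond acceptors, yet this read-out does not separate the two compounds, so at this position the exchange leaves no clear mark. No independent measurement here speaks to why the two rings read alike.

This single pair leaves open whether the position would accept a group of a different kind, such as a morpholine ring, a simple amine or a longer alkyl chain. It also leaves open whether a carboxylic acid on the ring would read the same.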